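This account rests on a few compounds, and the source may have more. Where it says the series, first, only, none or still open, it means among the compounds named here.

Measured so far:
Compound 1 `CS/C(=N\C(=O)c1ccco1)NC(=O)c1ccco1` — in a functional assay on PC-3 cells (Homo sapiens) for cytotoxicity, read by MTT assay, with a stated time of 72 h (a higher number here means that more compound is tolerated, a lower number that less compound is tolerated), compound 1 gives > 100000 nM, which is a limit of the assay and not a number.
Compound 2 `O=C(/N=C(/NC(=O)c1cc(-c2ccccc2)nc2ccccc12)[Se]Cc1ccccc1)c1cc(-c2ccccc2)nc2ccccc12` — compound 2 gives > 100000 nM, again only a limit.
Compound 3 `CS/C(=N\C(=O)c1cc(-c2ccccc2)nc2ccccc12)NC(=O)c1cc(-c2ccccc2)nc2ccccc12` — compound 3 gives > 100000 nM, also a limit.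

The step that the two limits leave unreadable from compound 3 to compound 2 corresponds to the change (a group of 8 heavy atoms (7 carbon, 1 selenium; one six-membered aromatic ring of carbon only) in place of a group of 2 heavy atoms (1 carbon, 1 sulfur; no ring), on a carbon with a double bond to nitrogen). Its size is not readable because of the limit of > 100000 nM in this assay, at which 3 of the 3 values shown sit. The same change, (a group of 8 heavy atoms (7 carbon, 1 selenium; one six-membered aromatic ring of carbon only) in place of a group of 2 heavy atoms (1 carbon, 1 sulfur; no ring), on a carbon with a double bond to nitrogen), leads from compound 1 to the not yet measured compound 4 `O=C(/N=C(/NC(=O)c1ccco1)[Se]Cc1ccccc1)c1ccco1`; the place is described in the same words for both pairs. How the core of compound 1 differs from the core of compound 3 is not broken down here.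

For this assay the step of a number no higher from compound 1 to compound 4 (the limit leaves the size open) is expected to be flat. Compound 4 is estimated at 100000 nM, between 30000 nM and 300000 nM. This rests on compound 1 giving > 100000 nM, a limit, so a limit is again the most likely outcome.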

Compound 4, concentration lethal to 50% of the cells: 84800 nM
Compound 4: the middle estimate sits 1.2-fold (0.07 log units) above what was measured, within the range that was stated.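

In this assay, putting the selenium-bearing group with its six-membered aromatic ring in place of methylsulfanyl, on a carbon with a double bond to nitrogen, gives an at least 1.1-fold lower number from compound 1 to compound 4 (0.07 log units; that floor lies within the scatter), so on the core of compound 1 no shift beyond the scatter is established. For compound 1, > 100000 nM is a limit and not a number. The same change from compound 3 to compound 2 cannot be read, so whether it carries from one core to the other is neither supported nor refuted, because the values at both ends of that step are limits: the limit of > 100000 nM in this assay, at which 3 of the 4 values shown sit.

The compounds shown leave open whether an amine or a longer alkyl chain on the same carbon would change this assay on either core. They also leave open what a benzyl group on sulfur would give, so the selenium and the ring are not separated.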